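Replacing thiophen-2-yl with 4-(trifluoromethyl)phenyl

The source may report more compounds than this note shows. Statements on the series, on what has been measured and on what is new or still open speak of the compounds shown alone.

Compound 1 `COc1cc(C(=O)c2sc(-c3ccc([N+](=O)[O-])cc3)cc2N)cc(OC)c1OC` gives 64 nM here
Compound 2 `COc1cc(C(=O)c2sc(-c3cccs3)cc2N)cc(OC)c1OC` gives 1.7 nM here

Both numbers come from a functional assay on FM3A cells (Mus musculus) for antiproliferative activity (a higher number here means a weaker inhibitor, a lower number a stronger inhibitor), and compound 2 holds the lower of the two, which makes it the stronger inhibitor of this pair. The next compound, compound 3 `COc1cc(C(=O)c2sc(-c3ccc(C(F)(F)F)cc3)cc2N)cc(OC)c1OC`, has not been measured. It differs from compound 2 as follows: 4-(trifluoromethyl)phenyl in place of thiophen-2-yl on an aromatic carbon with 4-(trifluoromethyl)phenyl in place of thiophen-2-yl on an aromatic carbon, next to the ring sulfur.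

Within the data shown here, only one measured step bears on this change. It is a 38-fold lower number from compound 1 to compound 2 (1.58 log units; beyond the scatter) and it is large, with thiophen-2-yl replacing 4-nitrophenyl. The new change runs the opposite way, from thiophen-2-yl back to a phenyl group with one substituent. Among the measured compounds shown here, no measurement yet compares 4-nitrophenyl with 4-(trifluoromethyl)phenyl, so this single step is only a rough guide. A large rise in this assay is therefore expected, slightly smaller than the measured step. The estimate is a 24-fold higher number from compound 2 to compound 3 (1.37 log units; beyond the scatter) as an expected step. For compound 3 the estimated value is 40 nM with an expected range from 10 nM to 150 nM in this estimate.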

Compound 3, half-maximal inhibitory concentration: 540 nM
Compound 3: middle estimate off by 14-fold (1.13 log units), on the low side, and the stated range ends below it.
By their numbers in this assay, from the lowest: compound 2; then compound 1; then compound 3.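

In this assay the place on the shared core next to the ring sulfur proves far less tolerant than the first pair suggested: putting 4-(trifluoromethyl)phenyl where thiophen-2-yl stood gives a 320-fold higher number from compound 2 to compound 3 (2.50 log units; beyond the scatter) and leaves compound 2 with the lowest number of the three. The two phenyl compounds also separate, since trifluoromethyl in place of nitro on the same phenyl ring gives an 8.4-fold higher number from compound 1 to compound 3 (0.93 log units; beyond the scatter) as a modest step beyond the scatter, so what the phenyl ring carries changes the result as well, and a phenyl ring at this place need not behave in one fixed way. Nothing in the information at hand tells what lies behind either step.

The compounds shown leave open how much of the rise belongs to replacing the thiophene ring and how much to the substituent, and a plain phenyl group with no substituent would separate the two. Also open, from the compounds shown here alone, is how a 4-methoxyphenyl group or thiophen-3-yl would fare at this place compared with thiophen-2-yl.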